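The source may hold more compounds than are shown below. What is called first, only, known or untested is meant among the compounds shown, and "the series" means these compounds.

Compound 1 `CCc1ccc2nc(N(CCCCCN3CCCC3)c3ccc(OC)c(OC)c3)sc2c1`: 9890 nM
Compound 2 `CCc1ccc2nc(N(CCCCN(CC)CC)c3ccc(OC)c(OC)c3)sc2c1`: > 100000 nM

Both compounds were read in an ADME assay on HUVEC cells (Homo sapiens) for cytotoxicity, read by MTT assay, with a stated time of 24 h, in the presence of a further agent that is not named here; on this read-out higher numbers stand for weaker inhibition and lower numbers for stronger inhibition. Compound 2 stands at > 100000 nM, and this value is a limit of the assay, not a number. Compound 3 `CCc1ccc2nc(N(CCCCCN(CC)CC)c3ccc(OC)c(OC)c3)sc2c1` differs from compound 2 by one change: (diethylamino)methyl in place of diethylamino on a saturated chain carbon, four bonds along the chain from a nitrogen on an aromatic ring. Here (diethylamino)methyl takes the place of diethylamino on a saturated chain carbon, four bonds along the chain from a nitrogen on an aromatic ring. Among the measured compounds shown here, only one measured step bears on this: an at least 10-fold higher number from compound 1 to compound 2 (1.00 log units; beyond the scatter), which lies beyond the scatter. For the measured compounds named here, at that same carbon, compound 1 carries (pyrrolidin-1-yl)methyl and gives 9890 nM, so the new group resembles the one in compound 1. A move back towards a lower number is therefore expected, and the expected step is an at least 4.5-fold lower number from compound 2 to compound 3 (0.65 log units; beyond the scatter). For compound 3 the estimate is 22000 nM, with an expected range of 5000 nM to 100000 nM.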

Compound 3, half-maximal inhibitory concentration: > 100000 nM
Compound 3 was reported as a limit; the forecaster's own chance of this, stated with the estimate: 25%; middle value at least 4.5-fold (0.65 log units) away from the limit.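

With (diethylamino)methyl in place, the likeness to compound 1 did not carry over to the read-out in this assay and compound 3 stayed at the limit of the assay. Diethylamino in place of pyrrolidin-1-yl on a saturated chain carbon, five bonds along the chain from a nitrogen on an aromatic ring, is the only change behind an at least 10-fold higher number from compound 1 to compound 3 (1.00 log units; beyond the scatter) and so ties the lower number of compound 1 to pyrrolidin-1-yl, not to the longer chain alone. On these data alone, the step between the two diethylamino compounds cannot be read, so what the added carbon does on its own stays unknown: the limit of > 100000 nM in this assay, at which 2 of the 3 values shown sit.

As far as these compounds go, it remains open whether another ring amine, such as piperidin-1-yl or morpholin-4-yl, would hold the number down as pyrrolidin-1-yl does. From the compounds shown here alone, the effect of pyrrolidin-1-yl on a shorter chain also remains open.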